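The source may report more compounds than this note shows. Statements on the series, on what has been measured and on what is new or still open speak of the compounds shown alone.

Of the compounds shown here, two have so far been tested in a functional assay on cells for agonist activity at Free fatty acid receptor 1 (Homo sapiens), read by calcium flux; a lower number here means that less compound is needed, a higher number that more compound is needed for the effect. Compound 1 `COC(CC(=O)O)c1ccc(OCc2cccc(-c3c(C)cccc3C)c2)s1` gives 210 nM in this assay. Compound 2 `Cc1cccc(C)c1-c1cccc(OCn2cc(CCC(=O)O)nn2)c1` gives 32200 nM in this assay. Of these two values, compound 1 holds the lower one, and its distance from compound 2 lies well beyond the usual scatter, so compound 1 is clearly the more potent of the pair.

Compound 3 `CCO[C@H](CC(=O)O)c1ccc(OCc2cccc(-c3c(C)cccc3C)c2)s1` has not yet been measured. It differs from compound 1 in a single spot: 2-carboxy-1-ethoxyethyl in place of 2-carboxy-1-methoxyethyl on an aromatic carbon. The ether part of the side chain thus grows by one carbon, and the stereocentre of that chain is now a single defined form. Among the measured compounds shown here, no pair of measured compounds shows what such a change does, so the expectation rests on the small size of the alteration alone. The step of a 1.4-fold lower number from compound 1 to compound 3 (0.15 log units; within the scatter) is expected to stay within the usual scatter, with perhaps a slight shift to a lower number. Compound 3 is therefore estimated at 150 nM, within a range from 50 nM to 500 nM.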

Compound 3, half-maximal effective concentration: 50 nM
Beside the measured number, compound 3's estimate is 3.0-fold (0.48 log units) above it; the measured number falls inside the stated range.
By their numbers in this assay, from the lowest: compound 3; then compound 1; then compound 2.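

In this assay, putting 2-carboxy-1-ethoxyethyl in place of 2-carboxy-1-methoxyethyl on the aromatic carbon next to the ring sulfur gives a 4.2-fold lower number from compound 1 to compound 3 (0.62 log units; beyond the scatter). Among the compounds shown here, this is the first comparison here between compounds that differ in only one place, and it shows that a small edit to this side chain can move the result by more than the usual scatter. Here, the larger ether part with one defined stereocentre goes with less compound being needed for the effect, but no supporting measurement is available to explain the gain.

This single step joins two changes, one extra carbon and one defined stereocentre, so the compounds shown cannot separate the contribution of each. Going by these compounds, it also remains open how the mirror-image form of compound 3 would compare, and whether a longer chain such as propoxy or a hydroxyl group at the same place would lower the number further or raise it.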